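Replacing an Alkyne with Iodine on a Shared Core

A few compounds are considered here, and "the series" means these few. Any claim that something is new, unique, unknown or untested is made for them only; others in the source may bear on it.

Compound 1 `CC(C)(C)OC(=O)NCC#Cc1ccc2c(c1)C=C([N+](=O)[O-])C(C(F)(F)F)O2`: 1250 nM
Compound 2 `CC(C)(C)C#Cc1ccc2c(c1)C=C([N+](=O)[O-])C(C(F)(F)F)O2`: 2100 nM

Both were tested in an assay on isolated protein for inhibition of D(1B) dopamine receptor (Homo sapiens); on this read-out lower numbers stand for stronger inhibition and higher numbers for weaker inhibition. Compound 2 has the highest of the two numbers, yet the step of a 1.7-fold higher number from compound 1 to compound 2 (0.23 log units; within the scatter) lies within the scatter, so the two compounds cannot be told apart on these data. Compound 3 `O=[N+]([O-])C1=Cc2cc(I)ccc2OC1C(F)(F)F` has not yet been measured. It differs from compound 2 by iodo in place of 3,3-dimethylbut-1-yn-1-yl on an aromatic carbon. No measured step bears directly on this change: the one step shown, a 1.7-fold higher number from compound 1 to compound 2 (0.23 log units; within the scatter), exchanges one group for another on a triple-bonded carbon while the triple bond stays, whereas here the whole triple-bonded group leaves and a single iodine enters. With no guide from the measured pair, the step of a 1.1-fold lower number from compound 2 to compound 3 (0.02 log units; within the scatter) is expected to be small, with a wide range to reflect the uncertainty. Compound 3 is estimated at 2000 nM, with a range from 500 nM to 8000 nM.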

Compound 3, inhibition constant: 1600 nM
Compound 3: middle estimate off by 1.3-fold (0.10 log units), on the high side, and the stated range covers the measured number.
By their numbers in this assay, from the lowest: compounds 1, 3 and 2 (each within the scatter of the next).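

Until now, the only step shown swapped one group for another while the triple bond stayed in place. Here the whole 3,3-dimethylbut-1-yn-1-yl group on the aromatic carbon gives way to a single iodo, and in this assay this gives a 1.3-fold lower number from compound 2 to compound 3 (0.12 log units; within the scatter) and so cannot be told from no change at all. At this position, then, the triple bond and its 6 carbon atoms are not needed for a number of this size, but nothing available explains this result.

As far as these compounds go, all three compounds keep the nitro and trifluoromethyl groups of the shared core, so the role of those groups remains open. From the compounds shown here alone, it is also open whether an amine, a carboxylic acid or a plain hydrogen on this aromatic carbon would move the number beyond the scatter.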